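Chain length on the oxime ether: compound 3 to compound 4

The source may report more compounds than this note shows. Statements on the series, on what has been measured and on what is new or still open speak of the compounds shown alone.

Measured compounds in a functional assay on HCT-116 cells (Homo sapiens) for inhibition, read by sulforhodamine B assay, with a stated time of 48 h; a lower number here means a stronger inhibitor, a higher number a weaker inhibitor:
compound 1 `CCOC(=O)CCO/N=C(/c1ccc(OC)c(OC)c1OC)c1cccc2ccccc12`, in this assay 10000 nM
compound 2 `COc1ccc(/C(=N/O)c2cccc3ccccc23)c(OC)c1OC`, in this assay 5880 nM
compound 3 `CCOC(=O)CO/N=C(/c1ccc(OC)c(OC)c1OC)c1cccc2ccccc12`, in this assay 3360 nM

Compound 3 gives the lowest number of the three. Its separation from compound 2 is within the scatter, so no order between them is claimed; against compound 1 the step of a 3.0-fold lower number from compound 1 to compound 3 (0.47 log units; beyond the scatter) is beyond the scatter and modest.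

Compound 4 `CCOC(=O)/C=C/CO/N=C(/c1ccc(OC)c(OC)c1OC)c1cccc2ccccc12` is not yet measured in this assay. The change from compound 3 is 2-(ethoxycarbonyl)ethenyl in place of ethoxycarbonyl on a saturated chain carbon bound to an oxygen on an unsaturated carbon.

The step that bears on this is a 3.0-fold lower number from compound 1 to compound 3 (0.47 log units; beyond the scatter), where shortening the chain from (ethoxycarbonyl)methyl to ethoxycarbonyl lowered the number. Compound 4 lengthens the chain again, by the two carbons of the ethenyl unit, so the reverse direction is expected. The step of a 1.8-fold lower number from compound 2 to compound 3 (0.24 log units; within the scatter) is within the scatter and gives no further guidance. Compound 4 is therefore expected to show a modest rise in number, estimated as a 1.9-fold higher number from compound 3 to compound 4 (0.29 log units; within the scatter). The estimate for compound 4 in this assay is 6500 nM, within 2500 nM to 16000 nM.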

Compound 4, half-maximal inhibitory concentration: > 20000 nM
Compound 4 gave a limit, no number; the forecaster's own chance of this, stated with the estimate: 10%; middle value at least 3.0-fold (0.48 log units) from the limit.
By their numbers in this assay, from the lowest: compounds 3, 2 and 1 (each within the scatter of the next, the first and the last beyond it). At a limit, above all of these: compound 4.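

In this assay compound 4 gives a limit, not a number: the limit of > 20000 nM in this assay, at which 1 of the 4 values shown sits.

With an at least 5.9-fold higher number from compound 3 to compound 4 (0.77 log units; beyond the scatter) and an at least 3.4-fold higher number from compound 2 to compound 4 (0.53 log units; beyond the scatter), this position now shows a chain on the oxygen that stands clearly worse than the hydrogen of compound 2, a separation the step from hydrogen to (ethoxycarbonyl)methyl did not show. Against the other ester, an at least 2.0-fold higher number from compound 1 to compound 4 (0.30 log units; that floor lies within the scatter) has a floor within the scatter, so no order between these two compounds is claimed.

Still open, on these data alone, is whether the rise goes with the added length or with the double bond, a question a saturated 3-(ethoxycarbonyl)propyl chain on the same oxygen would bear on. Also open, as far as these compounds go, is whether the ester matters at all, which a carboxylic acid or an amide at the chain end would test.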